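Trimming the Amide Aryl Group in Compound 2

A few compounds are considered here, and "the series" means these few. Any claim that something is new, unique, unknown or untested is made for them only; others in the source may bear on it.

In a functional assay on OVCAR-5 cells (Homo sapiens) for inhibition, read by sulforhodamine B assay, with a stated time of 48 h (a higher number here means a weaker inhibitor of growth, a lower number a stronger inhibitor of growth), compound 1 `O=C(Nc1cccc(-n2cc(-c3ccncc3)c(-c3ccc(Cl)c(O)c3)n2)c1)Nc1ccc(Cl)c(Cl)c1` gives 2400 nM. Compound 2 `COc1cc(-c2nn(-c3cccc(NC(=O)c4ccc(Cl)c(C(F)(F)F)c4)c3)cc2-c2ccncc2)ccc1Cl` reaches only a limit of the assay in this assay, > 32500 nM, so its true value is not known. This places compound 2 at the limit of > 32500 nM in this assay, at which 1 of the 2 values shown sits. Compound 3 `COc1cc(-c2nn(-c3cccc(NC(=O)c4ccccc4)c3)cc2-c2ccncc2)ccc1Cl` has not yet been measured. It differs from compound 2 in one place: phenyl in place of 4-chloro-3-(trifluoromethyl)phenyl on a carbonyl carbon. For the measured compounds named here, no measured pair shows this change, so its effect is unknown. In this assay the change is expected to be a step that the limit leaves unreadable from compound 2 to compound 3, nothing beyond the scatter. Compound 3 is therefore expected to give about 40000 nM in this assay, between 10000 nM and 160000 nM, and most likely again only a limit.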

Compound 3, concentration for 50% growth inhibition: 15000 nM
For compound 3 the middle estimate is 2.7-fold (0.43 log units) above the measured one; the measured number falls inside the stated range.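

On the carbonyl carbon of this amide, the bare phenyl does better than the larger 4-chloro-3-(trifluoromethyl)phenyl, with an at least 2.1-fold lower number from compound 2 to compound 3 (0.33 log units; beyond the scatter) in this assay. So the substituted ring is not needed for growth inhibition here, and compound 3 gives a readable number where compound 2 gave none. The full size of the step stays unknown because compound 2 stands at a limit of the assay: the limit of > 32500 nM in this assay, at which 1 of the 3 values shown sits.

From the compounds shown here alone, it remains open what a phenyl carrying only the chlorine or only the trifluoromethyl would give. Equally open, going by these compounds, is how a phenyl bearing an amine or a carboxylic acid would read at this position.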